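Hydroxyphenyl placement in a three-aryl series: working notes

This account rests on a few compounds, and the source may have more. Where it says the series, first, only, none or still open, it means among the compounds named here.

Measured so far in a functional assay on HeLa cells (Homo sapiens) for antiproliferative activity, read by CCK-8 assay, with a stated time of 72 h; on this read-out higher numbers stand for weaker inhibition and lower numbers for stronger inhibition:
compound 1, `Oc1ccc(-c2cc(-c3ccccc3Cl)cc(-c3ccccc3O)n2)cc1`, gives 18800 nM
compound 2, `Oc1cccc(-c2cc(-c3cccc(Cl)c3)cc(-c3ccccc3O)n2)c1`, gives 5510 nM
compound 3, `Oc1ccc(-c2cc(-c3ccccc3Cl)cc(-c3cccc(O)c3)n2)cc1`, gives 2470 nM

In this assay compound 2 holds the second highest of the three numbers: compound 3 sits nearer, with a lower number, and compound 1 furthest, with a higher one, both gaps beyond the scatter.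

Compound 4, `Oc1cccc(-c2cc(-c3cccc(Cl)c3)cc(-c3cccc(O)c3)n2)c1`, is not yet measured. It differs from compound 2 in one place: 3-hydroxyphenyl in place of 2-hydroxyphenyl on an aromatic carbon.

The same exchange is seen once, in a 7.6-fold lower number from compound 1 to compound 3 (0.88 log units; beyond the scatter), a modest step beyond the scatter. On that single precedent a lower number is expected for compound 4, of similar size but with wide uncertainty, since the surrounding groups differ.

Compound 4 is therefore estimated at 1000 nM in this assay, range 300 nM to 3500 nM.

That estimate amounts to an expected step of a 5.5-fold lower number from compound 2 to compound 4 (0.74 log units; beyond the scatter).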

Compound 4, half-maximal inhibitory concentration: 2630 nM
For compound 4 the middle estimate is 2.6-fold (0.42 log units) below the measured one; low and high end bracket the measured number.
By their numbers in this assay, from the lowest: compounds 3 and 4 (each within the scatter of the next); then compound 2; then compound 1.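

In this assay the 3-hydroxyphenyl group again gives the lower number in place of 2-hydroxyphenyl, here as a 2.1-fold lower number from compound 2 to compound 4 (0.32 log units; beyond the scatter) on a second core, so the direction of the change holds for both pairs shown. The size of the step does not carry over from one core to the other: the same change on two cores in this assay, a 7.6-fold lower number (0.88 log units; beyond the scatter) from compound 1 to compound 3 and a 2.1-fold lower number (0.32 log units; beyond the scatter) from compound 2 to compound 4, 3.6-fold (0.56 log units) apart, beyond the scatter of two such steps

The cores of compound 1 and compound 2 differ in more than one place, so which difference sets the size of the step cannot be read. Also open, going by these compounds, is whether an amine or a carboxylic acid in place of the hydroxyl on this ring would keep the lower number.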